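The source may report more compounds than this note shows. Statements on the series, on what has been measured and on what is new or still open speak of the compounds shown alone.

In an ADME assay on the whole organism (Mus musculus, strain ICR) for pharmacokinetics, at a dose of 50 mg/kg by the oral route (on this read-out lower numbers stand for lower exposure and higher numbers for higher exposure at the dose given), the measured compounds stand as follows:
- compound 1 `O=C1CC(Oc2ncccn2)CN1c1cnn2c1CN(C(=O)Nc1cc(F)c(F)c(F)c1)C(C1CC1)C2` gives 4020 ng.h/mL
- compound 2 `O=C1CC(c2ncco2)CN1c1cnn2c1CN(C(=O)Nc1cc(F)c(F)c(F)c1)C(C1CC1)C2` gives 12200 ng.h/mL
- compound 3 `C[C@H]1Cn2ncc(N3CC(c4ccccc4)CC3=O)c2CN1C(=O)Nc1cc(F)c(F)c(F)c1` gives 6510 ng.h/mL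

Compound 1 and compound 3 lie within the scatter of each other, while compound 2 stands clear of compound 1. Compound 4 `O=C1CC(c2ncccn2)CN1c1cnn2c1CN(C(=O)Nc1cc(F)c(F)c(F)c1)C(C1CC1)C2` is still unmeasured. It puts pyrimidin-2-yl in place of (pyrimidin-2-yl)oxy on a saturated ring carbon of compound 1 (pyrimidin-2-yl in place of (pyrimidin-2-yl)oxy on a saturated ring carbon). Going by the values given here, the one measured step at this place is a 3.0-fold higher number from compound 1 to compound 2 (0.48 log units; beyond the scatter), but its entering group is 1,3-oxazol-2-yl, so only part of that rise is assumed to carry over. The expected change is a smaller rise, estimated as a 2.0-fold higher number from compound 1 to compound 4 (0.30 log units; within the scatter). For compound 4 the expected value is 8000 ng.h/mL, with an estimated range from 3500 ng.h/mL to 18000 ng.h/mL.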

Compound 4, area under the concentration-time curve: 5070 ng.h/mL
Estimate against measurement, compound 4: 1.6-fold (0.20 log units) above; low and high end bracket the measured number.
By their numbers in this assay, from the lowest: compounds 1, 4, 3 and 2 (each within the scatter of the next, the first and the last beyond it).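

In this assay, pyrimidin-2-yl in place of (pyrimidin-2-yl)oxy gives a 1.3-fold higher number from compound 1 to compound 4 (0.10 log units; within the scatter) and so the loss of the oxygen alone does not separate these two compounds. On the same saturated ring carbon, pyrimidin-2-yl in place of 1,3-oxazol-2-yl gives a 2.4-fold lower number from compound 2 to compound 4 (0.38 log units; beyond the scatter) and so the higher exposure of compound 2 goes with the 1,3-oxazol-2-yl group, not simply with the absence of the oxygen. Nothing available explains this difference between the two rings. The compounds shown leave open whether 1,3-thiazol-2-yl or a simple amine on this ring carbon would match compound 2.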